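Replacing 1H-imidazol-1-yl with isopropylamino on a shared core

This account rests on a few compounds, and the source may have more. Where it says the series, first, only, none or still open, it means among the compounds named here.

Values measured in a functional assay on HeLa cells (Homo sapiens) for antiproliferative activity, read by WST assay, with a stated time of 24 h (on this read-out lower numbers stand for stronger inhibition and higher numbers for weaker inhibition), so far:
Compound 1 `C=C[C@]1(C)CC[C@@H](C(=C)COCCOC)C[C@H]1C(=C)C` gives 238000 nM
Compound 2 `C=C[C@]1(C)CC[C@@H](C(=C)Cn2ccnc2)C[C@H]1C(=C)C` gives 15700 nM

Of these two, compound 2 holds the lower number (15700 nM). Compound 3 `C=C[C@]1(C)CC[C@@H](C(=C)CNC(C)C)C[C@H]1C(=C)C` has not yet been measured. It carries isopropylamino in place of 1H-imidazol-1-yl on a saturated chain carbon bound to a double-bonded chain carbon. For the measured compounds named here, one measured step bears on this place: a 15-fold lower number from compound 1 to compound 2 (1.18 log units; beyond the scatter), a large step beyond the scatter, where 1H-imidazol-1-yl replaced 2-methoxyethoxy. That step shows the number in this assay can move widely with the group held here. Going by the values given here, no measured compound carries isopropylamino, however, so the data give no direction for this change. The step expected is therefore a 1.3-fold lower number from compound 2 to compound 3 (0.12 log units; within the scatter) and no shift beyond the scatter is estimated. Compound 3 is expected at 12000 nM (estimated range 4000 nM to 40000 nM)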

Compound 3, half-maximal inhibitory concentration: 40 nM
Beside the measured number, compound 3's estimate is 300-fold (2.48 log units) above it; the whole stated range lies above it.
By their numbers in this assay, from the lowest: compound 3; then compound 2; then compound 1.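

At this position the group decides far more than compounds 1 and 2 could show: in this assay, isopropylamino in place of 1H-imidazol-1-yl gives a 390-fold lower number from compound 2 to compound 3 (2.59 log units; beyond the scatter), and in place of 2-methoxyethoxy it gives a 6000-fold lower number from compound 1 to compound 3 (3.77 log units; beyond the scatter). The imidazole is therefore not the best of these groups, and the lack of a ring does not by itself go with a low number, since compound 1 also has no ring at this place yet holds the highest number of the three. Nothing available explains why this change has so large an effect.

The compounds shown leave open whether the low number is particular to isopropylamino or extends to other amines, such as dimethylamino or cyclohexylamino. From the compounds shown here alone, how a carboxylic acid or a longer chain would read at this place also remains open.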